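From benzyloxy to trifluoromethyl: a step without a number

The compounds below may be only part of what the source reports. "The series", "measured", "known", "first", "only" and "open" are said of these compounds alone.

Measured so far in an ADME assay on MT4 cells (Homo sapiens) for cytotoxicity, read by MTT assay, with a stated time of 3 days; a higher number here means that more compound is tolerated, a lower number that less compound is tolerated
Compound 1 `CC(C)(C)N(CCCc1ccccc1)C(=O)COC(=O)c1ccc([N+](=O)[O-])o1` | "not active" (no number reported)
Compound 2 `CC(C)(C)N(Cc1ccc([N+](=O)[O-])cc1)C(=O)COC(=O)c1ccc([N+](=O)[O-])o1` | > 100000 nM
Compound 3 `CC(C)(C)N(Cc1ccc(OCc2ccccc2)cc1)C(=O)COC(=O)c1ccc([N+](=O)[O-])o1` | "not active" (no number reported)

In this assay compound 3 is reported as "not active" (no number reported) with no number attached, so it offers no exact starting point. Compound 1 carries the same entry, "not active" (no number reported) in its case, and again no number. The value of compound 2, > 100000 nM as shown, is a limit of the assay and not a number. None of the three measured compounds therefore gives a firm figure.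

Compound 4 `CC(C)(C)N(Cc1ccc(C(F)(F)F)cc1)C(=O)COC(=O)c1ccc([N+](=O)[O-])o1` has not yet been measured. The structural change is trifluoromethyl in place of benzyloxy on an aromatic carbon and puts trifluoromethyl in place of benzyloxy on an aromatic carbon, para to a large group. Within the data shown here, no pair of measured compounds differs by this change alone.

The expectation in this assay is for no step beyond the scatter, in either direction. It rests on compound 2, whose > 100000 nM is a limit and not a number. Compound 4 may well be reported only as a limit too. As a number, compound 4 is expected at about 100000 nM with an estimated range from 30000 nM to 200000 nM in this reading.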

Compound 4, half-maximal cytotoxic concentration: 71000 nM
Estimate against measurement, compound 4: 1.4-fold (0.15 log units) above, within the range that was stated.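

In this assay compound 4 gives 71000 nM, the first exact number among the compounds shown, so a group on this aromatic carbon, para to a large group, can now be tied to a measured figure. Compound 2, which carries nitro in that place, is reported as > 100000 nM, and this is a limit and not a number. Trifluoromethyl in place of nitro therefore reads as an at least 1.4-fold lower number from compound 2 to compound 4 (0.14 log units; that floor lies within the scatter), which is a floor and not the full size of the step, because its starting value is a limit: the limit of > 100000 nM in this assay, at which 1 of the 4 values shown sits.

The step from benzyloxy to trifluoromethyl cannot be read, since compound 3 is reported as "not active" (no number reported) and gives no figure to compare with compound 4. From the compounds shown here alone, it also stays open what an amine, a carboxylic acid or a longer chain in this place would give in this assay, and whether any such group would shift the number beyond the usual scatter.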